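Working notes: compound 3 to compound 4

The source may report more compounds than this note shows. Statements on the series, on what has been measured and on what is new or still open speak of the compounds shown alone.

In a functional assay on MGC-803 cells (Homo sapiens) for antiproliferative activity, read by MTT assay, with a stated time of 72 h (a higher number here means a weaker inhibitor, a lower number a stronger inhibitor), compound 3 (`Cc1cccc(-c2nc(CNc3ccc(C(=O)NO)cc3)n(-c3ccccc3)n2)c1`) gives 8710 nM. Compound 1 (`O=C(NO)c1ccc(NCc2nc(-c3ccc(Cl)cc3)nn2-c2ccccc2)cc1`) gives 5970 nM and compound 2 (`O=C(NO)c1ccc(NCc2nc(-c3ccc(F)cc3)nn2-c2ccccc2)cc1`) gives 8960 nM, so all three lie within the scatter of each other.

Compound 4 (`Cc1ccsc1-c1nc(CNc2ccc(C(=O)NO)cc2)n(-c2ccccc2)n1`) carries 3-methylthiophen-2-yl in place of 3-methylphenyl on an aromatic carbon.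

For the measured compounds named here, no measured compound carries this group. The nearest evidence is the swaps on the same carbon, a 1.5-fold higher number from compound 1 to compound 3 (0.16 log units; within the scatter) and a 1.0-fold lower number from compound 2 to compound 3 (0.01 log units; within the scatter), along with a 1.5-fold higher number from compound 1 to compound 2 (0.18 log units; within the scatter), all within the scatter. No step beyond the scatter is therefore expected in this assay.

The expected step is a 1.2-fold lower number from compound 3 to compound 4 (0.06 log units; within the scatter).

Compound 4 is estimated at 7500 nM, with an expected range of 3500 nM to 16000 nM.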

Compound 4, half-maximal inhibitory concentration: 8890 nM
The estimate for compound 4 lay 1.2-fold (0.07 log units) below the measured number, within the range that was stated.
By their numbers in this assay, from the lowest: compounds 1, 3, 4 and 2 (each within the scatter of the next).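

In this assay, for the compounds shown here, the first group on this carbon that is not a substituted phenyl, 3-methylthiophen-2-yl, gives no step beyond the scatter against any of the three phenyl groups (a 1.0-fold higher number from compound 3 to compound 4 (0.01 log units; within the scatter); a 1.0-fold lower number from compound 2 to compound 4 (0.00 log units; within the scatter); a 1.5-fold higher number from compound 1 to compound 4 (0.17 log units; within the scatter)). Exchanging the six-membered carbon ring for a five-membered ring with sulfur therefore leaves the number within the scatter of the whole set. No supporting measurement bears on this result.

Still open, on these data alone, is whether an amine, a carboxylic acid or a longer alkyl chain on this carbon would produce a step beyond the scatter.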